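Swapping dimethylamino for methyl on a pyran series

This account rests on a few compounds, and the source may have more. Where it says the series, first, only, none or still open, it means among the compounds named here.

Measured compounds:
compound 1 `N#CC1=C(N)OC(c2c[nH]c3ccccc23)=C(C#N)C1c1ccccc1F`: "not active" (no number reported)
compound 2 `N#CC1=C(N)OC(c2c[nH]c3ccccc23)=C(C#N)C1c1ccc2ccccc2c1`: "not active" (no number reported)
compound 3 `CN(C)c1ccc(C2C(C#N)=C(N)OC(c3c[nH]c4ccccc34)=C2C#N)cc1`: 26.7%

In a functional assay, tested at 400 ug/mL (on this read-out higher numbers stand for a stronger effect at the one concentration tested and lower numbers for a weaker effect), compound 1 is reported as "not active" (no number reported), and compound 2 likewise as "not active" (no number reported), neither with a number. Going by the values given here, compound 3 is the one compound of the three with a reported figure, giving 26.7% in this assay, so it stands alone at the top of what has been measured.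

Compound 4 `Cc1ccc(C2C(C#N)=C(N)OC(c3c[nH]c4ccccc34)=C2C#N)cc1` differs from compound 3 in one place: methyl in place of dimethylamino on an aromatic carbon.

Among the compounds with values here, no step between two measured compounds is available here. Two of three compounds gave no number at all, and compound 3 carries the only figure. The step from compound 3 to compound 4 is expected to be downward, on the order of a number 13.7 percentage points lower from compound 3 to compound 4 (beyond the scatter), around the edge of the usual scatter. Compound 4 is estimated at 13%, within 0% to 28%, with a fair chance of no number being reported.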

Compound 4, a percentage reported as activity, at one concentration (the size of the read-out at that concentration, not a potency): 8.5%
The estimate for compound 4 lay 4.5 percentage points above the measured number; the measured number falls inside the stated range.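

Going by these compounds alone, the first step that can be read at this position shows that the group on the aromatic carbon para to a large group matters in this assay: the change from dimethylamino to methyl gives a number 18.2 percentage points lower from compound 3 to compound 4 (beyond the scatter). Even so, the 4-methylphenyl compound 4 still gives a number, 8.5%, so the effect is reduced rather than lost. Nothing available explains this drop.

Going by these compounds, whether a methoxy group, a primary amine or diethylamino at this place would give a result closer to compound 3 or to compound 4 remains open.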